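From Formylthiophene to Difluoromethylpyrazole on a Shared Core

The source may hold more compounds than are shown below. What is called first, only, known or untested is meant among the compounds shown, and "the series" means these compounds.

In a functional assay on MV4-11 cells (Homo sapiens) for inhibition, read by resazurin assay, with a stated time of 72 h (a higher number here means a weaker inhibitor of growth, a lower number a stronger inhibitor of growth), compound 1 `CC(=O)c1ccc(-c2cncc(Cl)c2N2CCC3(CCNC3=O)CC2)s1` gives 1440 nM and compound 2 `O=Cc1cc(-c2cncc(Cl)c2N2CCC3(CCNC3=O)CC2)cs1` gives 730 nM. Only these two numbers exist so far, and they lie within the scatter of each other, so compound 2 cannot be ranked apart from compound 1. Compound 3 `O=C1NCCC12CCN(c1c(Cl)cncc1-c1cnn(C(F)F)c1)CC2` keeps the shared core and carries 1-(difluoromethyl)-1H-pyrazol-4-yl in place of 5-formylthiophen-3-yl on an aromatic carbon. Within the data shown here, one measured step bears on this change, and only indirectly: a 2.0-fold lower number from compound 1 to compound 2 (0.30 log units; within the scatter), an exchange of one thiophene group for another at the same place. Among the measured compounds shown here, no measured compound carries a pyrazole, so the data offer no sign of direction. The expected change is a 1.1-fold higher number from compound 2 to compound 3 (0.04 log units; within the scatter), which means no shift beyond the scatter is anticipated. The estimate for compound 3 is 800 nM, with an expected range of 250 nM to 2500 nM.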

Compound 3, concentration for 50% growth inhibition: 6140 nM
Estimate against measurement, compound 3: 7.7-fold (0.89 log units) below, and the stated range ends below it.
By their numbers in this assay, from the lowest: compounds 2 and 1 (each within the scatter of the next); then compound 3.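

In this assay, this position on the six-membered aromatic ring proves sensitive to the group it carries: 1-(difluoromethyl)-1H-pyrazol-4-yl in place of 5-formylthiophen-3-yl gives an 8.4-fold higher number from compound 2 to compound 3 (0.92 log units; beyond the scatter), and in place of 5-acetylthiophen-2-yl it gives a 4.3-fold higher number from compound 1 to compound 3 (0.63 log units; beyond the scatter). The exchange between the two thiophene groups had stayed within the scatter, whereas the pyrazole separates compound 3 from both thiophene compounds. Nothing available accounts for this shift.

On these data alone, it remains open whether the higher number goes with the pyrazole ring itself or with its difluoromethyl group, and a methyl group or a plain hydrogen on that ring nitrogen would bear on this. Also open, as far as these compounds go, is whether the carbonyl on either thiophene matters, a question that an unsubstituted thiophene or one carrying a nitrile would address.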